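A few compounds are considered here, and "the series" means these few. Any claim that something is new, unique, unknown or untested is made for them only; others in the source may bear on it.

Working notes on the series in an assay on isolated protein with Bile acid receptor (Homo sapiens) as the target; on this read-out lower numbers stand for an effect already at smaller amounts and higher numbers for an effect only at larger amounts of compound. The reference here is compound 1, `COC(=O)/C=C/c1cccc(N(Cc2ccc(-c3cccc(C)c3)cc2)C(=O)C2CCCCC2)c1`, which carries a 3-methylphenyl on an aromatic carbon of the benzyl arm and gives 109 nM. Compound 2, `COC(=O)/C=C/c1cccc(N(Cc2ccc(Br)cc2)C(=O)C2CCCCC2)c1`, replaces that group with bromo; for compound 2 the assay reports only a limit, > 1000 nM. Compound 3, `COC(=O)/C=C/c1ccc(CN(C(=O)C2CCCCC2)c2cccc(/C=C/C(=O)OC)c2)cc1`, carries 2-(methoxycarbonyl)ethenyl at the same aromatic carbon. For compound 3 the assay likewise reports only a limit, > 1000 nM, so compound 3 stands at the weak end of what has been measured. Both changes away from compound 1 cost activity: an at least 9.1-fold higher number from compound 1 to compound 2 (0.96 log units; beyond the scatter) and an at least 9.1-fold higher number from compound 1 to compound 3 (0.96 log units; beyond the scatter). The step between compound 2 and compound 3 cannot be read, since (the limit of > 1000 nM in this assay, at which 2 of the 3 values shown sit).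

Compound 4, `COC(=O)/C=C/c1cccc(N(Cc2ccc(/C=C/c3ccc(F)cc3)cc2)C(=O)C2CCCCC2)c1`, differs from compound 3 by 4-fluorophenyl in place of methoxycarbonyl on a double-bonded chain carbon bound to a double-bonded chain carbon. Relative to compound 3 this restores an aromatic ring at the end of the benzyl arm, as in compound 1, whose value 109 nM anchors the expectation. The step from compound 1 to compound 3, an at least 9.1-fold higher number from compound 1 to compound 3 (0.96 log units; beyond the scatter), is the measured step that bears on this change, though in the reverse sense. The expected step is therefore a return toward compound 1, an at least 4.0-fold lower number from compound 3 to compound 4 (0.60 log units; beyond the scatter). Compound 4 is estimated at 250 nM, with a range of 70 nM to 1500 nM.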

Compound 4, half-maximal effective concentration: 185 nM
Compound 4: the middle estimate sits 1.4-fold (0.13 log units) above what was measured; the range from low to high includes it.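

In this assay, 4-fluorophenyl in place of methoxycarbonyl on the ethenyl chain gives an at least 5.4-fold lower number from compound 3 to compound 4 (0.73 log units; beyond the scatter), and the whole 2-(4-fluorophenyl)ethenyl in place of bromo gives an at least 5.4-fold lower number from compound 2 to compound 4 (0.73 log units; beyond the scatter). Compared with the 3-methylphenyl, the same group gives a 1.7-fold higher number from compound 1 to compound 4 (0.23 log units; within the scatter), so this aromatic carbon carries a terminal aromatic ring either directly or through an ethenyl link, without a difference beyond the scatter. The true size of the first two steps stays unread because each starts from a compound reported only as a limit: the limit of > 1000 nM in this assay, at which 2 of the 4 values shown sit.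

The compounds shown leave open whether the fluorine contributes anything, or whether an unsubstituted phenyl on the same ethenyl chain would read alike. Also open, on these data alone, is how an amine or a carboxylic acid at the end of this arm would read.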